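This account rests on a few compounds, and the source may have more. Where it says the series, first, only, none or still open, it means among the compounds named here.

Measured in a functional assay on BT-474 cells (Homo sapiens) for inhibition, read by fluorescence, with a stated time of 72 h; on this read-out higher numbers stand for weaker inhibition of growth and lower numbers for stronger inhibition of growth:
- compound 1 `COc1ccc(Nc2nc(N[C@H]3CC[C@H](N)CC3)nc3c2ncn3CCC(C)C)c(OC)c1`: 7900 nM
- compound 2 `CC(C)CCn1cnc2c(Nc3ccc(Cl)cc3)nc(N[C@H]3CC[C@H](N)CC3)nc21`: 5100 nM
- compound 3 `CCCCCCn1cnc2c(Nc3ccc(Cl)cc3)nc(N[C@H]3CC[C@H](N)CC3)nc21`: 5500 nM

Compound 3 lies within the scatter of both other compounds, so the three values do not separate. Next is compound 4 `N[C@H]1CC[C@H](Nc2nc(Nc3ccc(Cl)cc3)c3ncn(C4CCCCC4)c3n2)CC1`, with this change from compound 3: cyclohexyl in place of hexyl on an aromatic nitrogen. In words, cyclohexyl in place of hexyl on an aromatic nitrogen. The closest evidence is a 1.1-fold higher number from compound 2 to compound 3 (0.03 log units; within the scatter), a change within the chain on that nitrogen. The aryl change, a 1.5-fold lower number from compound 1 to compound 2 (0.19 log units; within the scatter), sits elsewhere and is equally small. Among the measured compounds shown here, no measured compound carries a ring at this place, so the evidence is indirect. The expected step is a 1.2-fold lower number from compound 3 to compound 4 (0.09 log units; within the scatter), with nothing expected beyond the scatter. For compound 4 the estimate in this assay is 4500 nM, with an expected range of 1500 nM to 10000 nM.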

Compound 4, concentration for 50% growth inhibition: 4100 nM
The estimate for compound 4 lay 1.1-fold (0.04 log units) above the measured number; low and high end bracket the measured number.
By their numbers in this assay, from the lowest: compounds 4, 2, 3 and 1 (each within the scatter of the next).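

In this assay cyclohexyl, the only ring on the aromatic nitrogen among these compounds, gives a 1.3-fold lower number from compound 3 to compound 4 (0.13 log units; within the scatter) against hexyl and a 1.2-fold lower number from compound 2 to compound 4 (0.09 log units; within the scatter) against isopentyl and so stays within the scatter of both open chains. At this place, closing the six carbons into a ring therefore does not separate from either chain. Nothing measured here offers an explanation for this flat result.

On these data alone, whether a methyl group or a chain ending in an amine or a carboxylic acid on this nitrogen would move the number beyond the scatter remains open. Also open, as far as these compounds go, is how cyclohexyl behaves alongside 2,4-dimethoxyphenyl in place of 4-chlorophenyl.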